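Changing the Aryl Ring on a Sulfonyl Sulfur

This account rests on a few compounds, and the source may have more. Where it says the series, first, only, none or still open, it means among the compounds named here.

Measured so far in an assay on cells for inhibition of HSP60/HSP10 (Homo sapiens), with a stated time of 60 min; on this read-out higher numbers stand for weaker inhibition and lower numbers for stronger inhibition:
- compound 1 `O=S(=O)(Nc1ccc2oc(-c3ccc(NS(=O)(=O)c4cccc5nonc45)cc3)nc2c1)c1ccc(Cl)s1`: 13000 nM
- compound 2 `O=S(=O)(Nc1ccc(-c2nc3ccccc3o2)cc1)c1cccc(Cl)c1`: 54000 nM
- compound 3 `O=S(=O)(Nc1ccc(-c2nc3ccccc3o2)cc1)c1cccc(C(F)(F)F)c1`: 57000 nM

Compound 2 has the second highest of the three numbers. Compound 3 sits nearest, a 1.1-fold higher number from compound 2 to compound 3 (0.02 log units; within the scatter), so the two cannot be told apart. Compound 1 is the furthest away, and its lower number lies beyond the scatter.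

Compound 4 `O=S(=O)(Nc1ccc(-c2nc3ccccc3o2)cc1)c1ccc(F)cc1` has not been measured. It differs from compound 2 in one place: 4-fluorophenyl in place of 3-chlorophenyl on a sulfonyl sulfur.

Within the data shown here, only one measured step concerns the same part of the molecule, the ring on the sulfonyl sulfur: a 1.1-fold higher number from compound 2 to compound 3 (0.02 log units; within the scatter), a change that stayed within the scatter. On this thin basis the change from compound 2 to compound 4 is expected to give no step beyond the scatter, so a 1.1-fold lower number from compound 2 to compound 4 (0.03 log units; within the scatter) is the expected result. Compound 4 is therefore estimated at 50000 nM, with a range from 20000 nM to 125000 nM.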

Compound 4, half-maximal inhibitory concentration: 73000 nM
Compound 4: the middle estimate sits 1.5-fold (0.16 log units) below what was measured; the range from low to high includes it.
By their numbers in this assay, from the lowest: compound 1; then compounds 2, 3 and 4 (each within the scatter of the next).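

In this assay a swap that alters both the halogen and its place on the phenyl ring gives a 1.4-fold higher number from compound 2 to compound 4 (0.13 log units; within the scatter) and so cannot be told apart from no change. This is the second replacement of the ring on the sulfonyl sulfur that stays within the scatter of compound 2, so compounds 2, 3 and 4 form one group of similar, weak numbers, and neither the kind of halogen nor its place has yet made a readable difference. Nothing shown here explains why these changes make so little difference.

Still open, going by these compounds, is whether an amine or a carboxylic acid on this phenyl ring would give a step beyond the scatter. The same question stands for a ring other than phenyl on the sulfonyl sulfur of this core.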